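The compounds below may be only part of what the source reports. "The series", "measured", "known", "first", "only" and "open" are said of these compounds alone.

In a functional assay on HeLa cells (Homo sapiens) for antiproliferative activity, read by MTT assay, with a stated time of 72 h (on this read-out higher numbers stand for weaker inhibition and lower numbers for stronger inhibition), compound 3 `Nc1nc(N)c2cc(CSC(=S)N3CCN(c4ccccc4[N+](=O)[O-])CC3)ccc2n1` gives 4880 nM. Compound 1 `Cc1ccc(N2CCN(C(=S)SCc3ccc4nc(N)nc(N)c4c3)CC2)c(C)c1` gives 3190 nM, and compound 2 `Nc1nc(N)c2cc(CSC(=S)N3CCN(c4ccc(F)cc4)CC3)ccc2n1` gives 1840 nM. Compound 3 separates only from compound 2: the series shows a 1.5-fold higher number from compound 1 to compound 3 (0.18 log units; within the scatter) and a 2.7-fold higher number from compound 2 to compound 3 (0.42 log units; beyond the scatter).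

The next change leads to compound 4 `Nc1nc(N)c2cc(CSC(=S)N3CCN(c4ncccn4)CC3)ccc2n1`: pyrimidin-2-yl in place of 2-nitrophenyl on an amine nitrogen in a ring, (pyrimidin-2-yl in place of 2-nitrophenyl on an amine nitrogen in a ring).

The three measured swaps at this same ring nitrogen bear on it. Besides the two steps above, there is a 1.7-fold lower number from compound 1 to compound 2 (0.24 log units; within the scatter). Only one of the three passes the scatter, and it is modest. Going by the values given here, no measured compound carries pyrimidin-2-yl, so the new group has no direct precedent here. In this assay a small step at most is therefore expected, with a slight lean towards a lower number, placing compound 4 among the three measured values.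

The expected step is a 1.6-fold lower number from compound 3 to compound 4 (0.21 log units; within the scatter). For compound 4 the estimate is 3000 nM, with an expected range of 1400 nM to 6500 nM.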

Compound 4, half-maximal inhibitory concentration: 4360 nM
Compound 4: middle estimate off by 1.5-fold (0.16 log units), on the low side; low and high end bracket the measured number.
By their numbers in this assay, from the lowest: compounds 2, 1, 4 and 3 (each within the scatter of the next, the first and the last beyond it).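

In this assay, going by these compounds alone, pyrimidin-2-yl is the only group at this ring nitrogen with hetero atoms in its aromatic ring, yet it cannot be told apart from 2-nitrophenyl (a 1.1-fold lower number from compound 3 to compound 4 (0.05 log units; within the scatter)) or from 2,4-dimethylphenyl (a 1.4-fold higher number from compound 1 to compound 4 (0.14 log units; within the scatter)). Against 4-fluorophenyl the picture differs (a 2.4-fold higher number from compound 2 to compound 4 (0.37 log units; beyond the scatter)): this is the second modest step at this position, and compound 2 stands at the low end of both. Among these four compounds, then, replacing a carbon-only aromatic ring with a pyrimidin-2-yl ring does not by itself separate compound 4 from compound 1 or compound 3, while compound 2 stays apart from compound 3 and compound 4 only.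

Nothing available gives a reason for the gap to compound 2. On these data alone, whether a benzyl group, an acetyl group or a plain methyl group on this nitrogen would stay within the same range remains open.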